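Removing the ring nitrogen methyl from a pyridinol ether

The compounds below may be only part of what the source reports. "The series", "measured", "known", "first", "only" and "open" are said of these compounds alone.

Among the compounds with values here, compound 1 `CN1CCC[C@H]1COc1cncc(O)c1` gives the lowest of the two numbers so far: in an assay on cell membranes for displacement of a labelled ligand from Neuronal acetylcholine receptor; alpha4/beta2 (Rattus norvegicus), read by scintillation counting (on this read-out lower numbers stand for stronger inhibition and higher numbers for weaker inhibition), compound 1 gives 3.7 nM, while compound 2 `COc1ncccc1OC[C@@H]1CCCN1C` gives 7280 nM in this assay, a gap beyond the scatter. Compound 3 `Oc1cncc(OC[C@@H]2CCCN2)c1` differs from compound 1 by hydrogen in place of methyl on an amine nitrogen in a ring. Within the data shown here, with no measured step of this kind at hand, the change from compound 1 to compound 3 is expected to be a 1.5-fold lower number from compound 1 to compound 3 (0.17 log units; within the scatter), nothing beyond the scatter. Compound 3 is estimated at 2.5 nM in this assay, between 0.5 nM and 15 nM.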

Compound 3, inhibition constant: 2.5 nM
Compound 3: middle estimate and measured number agree at the digits printed; the range from low to high includes it.
By their numbers in this assay, from the lowest: compounds 3 and 1 (each within the scatter of the next); then compound 2.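

In this assay the step with hydrogen in place of methyl on an amine nitrogen in a ring reads as a 1.5-fold lower number from compound 1 to compound 3 (0.17 log units; within the scatter). This first measured step at this position shows that, on the core of compound 1, a number this low does not depend on the methyl. Nothing at hand gives a reason for this result. From the compounds shown here alone, what an ethyl group or a longer chain on this nitrogen would do remains open. So does whether the same change would give a similar step on the core of compound 2.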